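The compounds below may be only part of what the source reports. "The series", "measured", "known", "first", "only" and "open" are said of these compounds alone.

Working notes on the series. Three compounds share one core carrying an adenosine-like sugar and an amino acid chain on a central amine nitrogen. Compound 1 `N=C(N)NCCCN(CC[C@H](N)C(=O)O)C[C@H]1O[C@@H](n2cnc3c(N)ncnc32)[C@H](O)[C@@H]1O` gives 56.5% in an assay on isolated protein for inhibition of histone-lysine N-methyltransferase SETD7 (Homo sapiens), read by scintillation counting, with a stated time of 90 min, tested at 100 uM; a higher number here means more inhibition at the concentration tested (going by the name of the read-out), a lower number less inhibition. Compound 2 `N=C(N)NCCCCN(CC[C@H](N)C(=O)O)C[C@H]1O[C@@H](n2cnc3c(N)ncnc32)[C@H](O)[C@@H]1O` gives 49% in this assay, and compound 3 `C#CCN(CC[C@H](NC(=O)OC(C)(C)C)C(=O)OC(C)(C)C)C[C@H]1O[C@@H](n2cnc3c(N)ncnc32)[C@@H]2OC(C)(C)O[C@@H]21` gives 63%. Among these three numbers compound 2 has the lowest; compound 1 is nearest, a number higher within the scatter, while compound 3 is furthest, a number higher beyond the scatter.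

Within the data shown here, the one measured step is a number 7.5 percentage points lower from compound 1 to compound 2 (within the scatter), a change from a group of 4 heavy atoms to a group of 5 heavy atoms on a saturated chain carbon three bonds along the chain from an amine nitrogen, which lies within the scatter.

Compound 4 `C#CCN(CC[C@H](N)C(=O)O)C[C@H]1O[C@@H](n2cnc3c(N)ncnc32)[C@H](O)[C@@H]1O` is not yet measured. From compound 2 it differs by a group of 2 heavy atoms (2 carbon; no ring) in place of a group of 7 heavy atoms (4 carbon, 3 nitrogen; no ring), on a saturated chain carbon bound to an amine nitrogen. Among the measured compounds shown here, no measured step covers a change of this kind; the step from compound 1 to compound 2 only altered the length of the leaving group and did not move the number beyond the scatter. Compound 3 carries the same ethynyl on its chain but is protected at the amine, the acid and the sugar hydroxyls, so its number is only a loose pointer. A step of about a number 6 percentage points higher from compound 2 to compound 4 (within the scatter) is therefore expected, most likely within the scatter. Compound 4 is estimated at 55%, between 35% and 75%.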

Compound 4, a percentage reported as inhibition, at one concentration (the size of the read-out at that concentration, not a potency): 75%
Compound 4: the middle estimate sits 20 percentage points below what was measured, within the range that was stated.
By their numbers in this assay, from the lowest: compounds 2, 1 and 3 (each within the scatter of the next, the first and the last beyond it); then compound 4.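

In this assay, putting ethynyl on the saturated chain carbon bound to an amine nitrogen gives a number 26 percentage points higher from compound 2 to compound 4 (beyond the scatter) and also a number 18.5 percentage points higher from compound 1 to compound 4 (beyond the scatter), so this position can carry a change that moves the read-out beyond the scatter. The earlier step at this position, a number 7.5 percentage points lower from compound 1 to compound 2 (within the scatter), altered only the length of the chain and left open whether the position mattered at all; the new steps show that the whole group of 6 or 7 heavy atoms, with its hydrogen-bond donors, can be replaced by a group of 2 carbon atoms without a loss of inhibition at the concentration tested. Nothing at hand gives a reason for the size of these steps.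

Open, from the compounds shown here alone, is whether ethynyl itself accounts for the steps or whether removing the larger group is enough, which an ethyl or a vinyl group in the same place would help to separate. Also open, going by these compounds, is which part of the larger group goes with the lower numbers, a question that a chain ending in a primary amine or in a carboxylic acid would address.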